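Changing the carbonyl substituent of compound 1

The source may hold more compounds than are shown below. What is called first, only, known or untested is meant among the compounds shown, and "the series" means these compounds.

Measured in a functional assay on HUVEC cells (Homo sapiens) for inhibition, with stated times of 2 h and 72 h; a higher number here means a weaker inhibitor, a lower number a stronger inhibitor:
- compound 1 `COc1cc2nccc(Oc3ccc4c(NC(=O)c5cccc(C(F)(F)F)c5)nn(C)c4c3)c2cc1OC` (9 nM)
- compound 2 `COc1ccc(C(=O)Nc2nn(C)c3cc(Oc4ccnc5cc(OC)c(OC)cc45)ccc23)cc1` (32 nM)
- compound 3 `COc1cc2nccc(Oc3ccc4c(NC(=O)Nc5ccc(C)cc5)nn(C)c4c3)c2cc1OC` (3 nM)

Compound 1 stands second highest of the three numbers, below compound 2 and above compound 3. Compound 4 `COc1ccc(NC(=O)Nc2nn(C)c3cc(Oc4ccnc5cc(OC)c(OC)cc45)ccc23)cc1` has (4-methoxyphenyl)amino in place of 3-(trifluoromethyl)phenyl on a carbonyl carbon and has not yet been measured. Placing (4-methylphenyl)amino there gave a modest step of a 3.0-fold lower number from compound 1 to compound 3 (0.48 log units; beyond the scatter). Placing 4-methoxyphenyl there gave a modest step the other way a 3.6-fold higher number from compound 1 to compound 2 (0.55 log units; beyond the scatter). The step of an 11-fold lower number from compound 2 to compound 3 (1.03 log units; beyond the scatter) is large. Compound 3 at 3 nM is the nearest guide. A modest step to a lower number is therefore expected, a 2.3-fold lower number from compound 1 to compound 4 (0.35 log units; beyond the scatter). For compound 4 the estimate is 4 nM, with an expected range from 1.5 nM to 12 nM.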

Compound 4, half-maximal inhibitory concentration: 7 nM
Compound 4: the middle estimate sits 1.8-fold (0.24 log units) below what was measured; the measured number falls inside the stated range.
By their numbers in this assay, from the lowest: compound 3; then compounds 4 and 1 (each within the scatter of the next); then compound 2.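

Within the data shown here, with 4-methoxyphenyl held in common, the amino link on the carbonyl carbon alone gives a step (a 4.6-fold lower number from compound 2 to compound 4 (0.66 log units; beyond the scatter)), a comparison the earlier compounds did not offer for this ring. Among the (aryl)amino compounds, methoxy in place of methyl on an aromatic carbon also registers (a 2.3-fold higher number from compound 3 to compound 4 (0.37 log units; beyond the scatter)), whereas the change from 3-(trifluoromethyl)phenyl to (4-methoxyphenyl)amino (a 1.3-fold lower number from compound 1 to compound 4 (0.11 log units; within the scatter)) cannot be distinguished from scatter. As far as these compounds go, whether a chlorine, a dimethylamino group or a carboxylic acid on that ring would keep this level stays open. No evidence is available that explains these steps.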